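A few compounds are considered here, and "the series" means these few. Any claim that something is new, unique, unknown or untested is made for them only; others in the source may bear on it.

Measured compounds:
- compound 1, `COc1ccc(N2C(=O)COc3ccc(-c4cnc5ccccc5c4)cc32)cc1`: > 40000 nM in a functional assay on HCT-116 cells (Homo sapiens) for antiproliferative activity, read by MTT assay, with a stated time of 72 h (on this read-out lower numbers stand for stronger inhibition and higher numbers for weaker inhibition), which is a limit of the assay and not a number
- compound 2, `O=C1COc2ccc(-c3cnc(Cl)c(NS(=O)(=O)c4ccc(F)cc4)c3)cc2N1c1ccc(F)cc1`: 34200 nM in this assay
- compound 3, `COc1ncc(-c2ccc3c(c2)N(c2ccc(F)cc2)C(=O)CO3)cc1NS(=O)(=O)c1ccc(F)cc1`: > 40000 nM in this assay, again a limit of the assay

Compound 1 therefore stands at the limit of > 40000 nM in this assay, at which 2 of the 3 values shown sit, so only a floor on its weakness is known. Compound 4, `O=C1COc2ccc(-c3cnc4ccccc4c3)cc2N1c1ccc(Cl)cc1`, differs from compound 1 in one place: chloro in place of methoxy on an aromatic carbon.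

Among the measured compounds shown here, only one measured pair speaks to the same kind of exchange, and it runs the other way, on an aromatic carbon of a different ring: an at least 1.1-fold higher number from compound 2 to compound 3 (0.06 log units; that floor lies within the scatter). That step did not leave the scatter, so swapping methoxy and chloro gave no clear movement there.

Given that, no shift beyond the scatter is expected in this assay for compound 4, which would keep it at the limit like compound 1. Compound 4 is therefore estimated at 40000 nM, with a range from 15000 nM to 100000 nM. The step this estimate implies is a number no higher from compound 1 to compound 4 (the limit leaves the size open), an expected standstill.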

Compound 4, half-maximal inhibitory concentration: 36100 nM
For compound 4 the middle estimate is 1.1-fold (0.04 log units) above the measured one; the range from low to high includes it.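

Among the compounds shown here, on the ring of the core that carries the 4-methoxyphenyl group, the change to 4-chlorophenyl gives in this assay an at least 1.1-fold lower number from compound 1 to compound 4 (0.04 log units; that floor lies within the scatter), the first reading of this exchange at this position, para to a large group. Going by these compounds, compound 1 is a limit of the assay and not a number, so only a floor on the step is known and its true size stays unknown. Set beside the earlier pair on a different ring, the exchange has shown no clear movement at either place so far: the same change on two cores in this assay, an at least 1.1-fold higher number (0.06 log units; that floor lies within the scatter) from compound 2 to compound 3 and an at least 1.1-fold higher number (0.04 log units; that floor lies within the scatter) from compound 4 to compound 1; the limit leaves it open whether they differ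

On these data alone, whether an amine or a carboxylic acid in place of the chloro on this ring would move the number clearly stays open. So does whether the exchange would behave the same way on a core that reads well clear of the limit.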